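Second methyl on the aryl ester of compound 1

The compounds below may be only part of what the source reports. "The series", "measured", "known", "first", "only" and "open" are said of these compounds alone.

Notes on the series. In an assay on NIH3T3 cells with Urotensin-2 receptor (Homo sapiens) as the target (a lower number here means that less compound is needed, a higher number that more compound is needed for the effect), compound 1 `Cc1ccccc1C(=O)OC(CCN(C)C)c1ccc(Cl)cc1` gives 1700 nM, the highest of the three numbers at hand. Compound 2 `CN(C)CCC(OC(=O)c1cn(C)c2ccccc12)c1ccc(Cl)cc1` gives 1510 nM in this assay, within the scatter of compound 1. Compound 3 `CN(C)CCC(OC(=O)c1ccc(-c2ccccc2)cc1)c1ccc(Cl)cc1` gives 525 nM in this assay, a lower number than compound 1 and beyond the scatter.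

Compound 4 `Cc1cccc(C(=O)OC(CCN(C)C)c2ccc(Cl)cc2)c1C` differs from compound 1 by methyl in place of hydrogen on an aromatic carbon, ortho to a methyl group and meta to a large group. Among the measured compounds shown here, no measured pair shows this step, so its size is unknown; the expectation is a small drop in the number, near the edge of the scatter. Compound 4 is estimated at 1100 nM in this assay, with a range from 450 nM to 2800 nM, a step of a 1.5-fold lower number from compound 1 to compound 4 (0.19 log units; within the scatter) expected from compound 1 to compound 4.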

Compound 4, half-maximal effective concentration: 1150 nM
The estimate for compound 4 lay 1.0-fold (0.02 log units) below the measured number, and the stated range covers the measured number.
By their numbers in this assay, from the lowest: compound 3; then compounds 4, 2 and 1 (each within the scatter of the next).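

In this assay, among the compounds shown here, the change from 2-methylphenyl to 2,3-dimethylphenyl gives a 1.5-fold lower number from compound 1 to compound 4 (0.17 log units; within the scatter) and is the first single-place comparison. A methyl on this aromatic carbon, ortho to a methyl group and meta to a large group, thus leaves the number indistinguishable from that of compound 1. No supporting measurement bears on this result.

Going by these compounds, whether an ethyl, methoxy or amine group on the same carbon would behave like methyl remains open. So does the effect of removing the existing methyl from 2-methylphenyl.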